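The source may report more compounds than this note shows. Statements on the series, on what has been measured and on what is new or still open speak of the compounds shown alone.

Of the compounds shown here, three built on one shared core have been measured in a functional assay on NCI-H226 cells (Homo sapiens) for inhibition, read by sulforhodamine B assay, with a stated time of 48 h; on this read-out higher numbers stand for weaker inhibition of growth and lower numbers for stronger inhibition of growth. Compound 1 `Nc1cc(N)c2nc(-c3ccccc3)c(Oc3ccc(Cl)c(Cl)c3)nc2c1` gives 49000 nM. Compound 2 `Nc1cc(N)c2nc(-c3ccccc3)c(NCc3ccc(Cl)c(Cl)c3)nc2c1` gives 46800 nM, and compound 3 `CCOC(=O)[C@H](CCC(=O)O)NC(=O)c1ccc(Sc2nc3cc(N)cc(N)c3nc2-c2ccccc2)cc1` gives 43700 nM. Compound 1 has the highest of the three numbers, but its gaps to compound 2 and to compound 3 both fall inside the usual scatter of repeated measurements, so on this read-out the three compounds cannot be told apart.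

The next compound, compound 4 `Nc1cc(N)c2nc(-c3ccccc3)c(Sc3ccc(Cl)c(Cl)c3)nc2c1`, is compound 1 with one change: (3,4-dichlorophenyl)sulfanyl in place of 3,4-dichlorophenoxy on an aromatic carbon. The link through oxygen is thus exchanged for a link through sulfur, while the rest of the molecule stays as it is. Within the data shown here, no pair of measured compounds differing in exactly one place is available to show what such a swap does here, and compound 3, which also joins its aromatic ring to the core through sulfur, gives a number within the scatter of compound 1. The expected step from compound 1 to compound 4 in this assay is therefore a 1.1-fold lower number from compound 1 to compound 4 (0.04 log units; within the scatter), that is, no change beyond the scatter. Compound 4 is estimated at 45000 nM, with a likely range from 15000 nM to 140000 nM.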

Compound 4, concentration for total growth inhibition: 9120 nM
Compound 4: the middle estimate sits 4.9-fold (0.69 log units) above what was measured, outside the stated range (below it).
By their numbers in this assay, from the lowest: compound 4; then compounds 3, 2 and 1 (each within the scatter of the next).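

In this assay, exchanging the oxygen link for a sulfur link gives a 5.4-fold lower number from compound 1 to compound 4 (0.73 log units; beyond the scatter), so this place on the shared core responds to a change of a single linking atom. The swap leaves the dichlorinated aromatic ring and the heavy-atom count of the group unchanged, and the rest of the molecule stays as it is, so the step belongs to the link itself. The earlier compounds offered no listed pair differing in one place and their numbers lay within the scatter of one another, so they gave no sign that this place could move the read-out, and no measurement shown here explains why this exchange has this effect.

The compounds shown leave open whether a methylene link or a sulfonyl link at the same place would give a number nearer to that of compound 4 or to that of compound 1. Going by these compounds, it also remains open whether the step would persist if the two chlorines on the ring were replaced by methoxy groups, or if a longer chain separated the sulfur from that ring.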